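Spirocyclic series: aryl swap on the triazole nitrogen

This account rests on a few compounds, and the source may have more. Where it says the series, first, only, none or still open, it means among the compounds named here.

Measured so far in an ADME assay on L02 cells (Homo sapiens) for antiproliferative activity, read by MTT assay, with a stated time of 48 h; a lower number here means a stronger inhibitor, a higher number a weaker inhibitor:
compound 1 `Cc1cccc(-n2nncc2CN2C(=O)C3(C(C#N)=C(N)Oc4c3c3nc5ccccc5nc3c3ccccc43)c3ccccc32)c1` gives > 50000 nM, a limit of the assay.
compound 2 `N#CC1=C(N)Oc2c(c3nc4ccccc4nc3c3ccccc23)C12C(=O)N(Cc1cnnn1-c1ccc(Br)cc1)c1ccccc12` gives > 50000 nM, a limit of the assay.
compound 3 `COc1ccccc1-n1nncc1CN1C(=O)C2(C(C#N)=C(N)Oc3c2c2nc4ccccc4nc2c2ccccc32)c2ccccc21` gives > 50000 nM, a limit of the assay.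

Compound 3 therefore stands at the same limit as the other two; none of the three shows a readable number. The step from compound 1 to compound 2 is a step that the two limits leave unreadable from compound 1 to compound 2, that from compound 1 to compound 3 is a step that the two limits leave unreadable from compound 1 to compound 3, and that from compound 2 to compound 3 is a step that the two limits leave unreadable from compound 2 to compound 3. Within the data shown here, the only evidence on these steps is the limit of > 50000 nM in this assay, at which 3 of the 3 values shown sit.

Compound 4 `N#CC1=C(N)Oc2c(c3nc4ccccc4nc3c3ccccc23)C12C(=O)N(Cc1cnnn1-c1ccc(N)cc1)c1ccccc12` is not yet measured. It differs from compound 3 by 4-aminophenyl in place of 2-methoxyphenyl on an aromatic nitrogen. Among the measured compounds shown here, all three measured steps bear on this change, since each swaps one aryl group on the same aromatic nitrogen, but each is unreadable, so no size of step in this assay can be inferred from them. The group that enters is still an aryl on the same nitrogen, and the three measured analogues with varied aryl groups all sit at the limit.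

Compound 4 is therefore expected to remain at or near the limit, with an estimated 60000 nM (range 25000 nM to 150000 nM), which would mean an estimated step that the limit leaves unreadable from compound 3 to compound 4 from compound 3.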

Compound 4, half-maximal inhibitory concentration: > 50000 nM
Compound 4 gave a limit, no number (the forecaster's own chance of this, stated with the estimate: 85%); the middle value lies beyond the limit too.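

In this assay compound 4 gives > 50000 nM, a limit and not a number. Its steps from compound 1, compound 2 and compound 3 cannot be read, so no new step follows: the limit of > 50000 nM in this assay, at which 4 of the 4 values shown sit.

The compounds shown leave open whether any aryl group on this aromatic nitrogen of the shared core gives a readable value in this assay.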